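This account rests on a few compounds, and the source may have more. Where it says the series, first, only, none or still open, it means among the compounds named here.

In a functional assay on 1A9 cells (Homo sapiens) for cytotoxicity (on this read-out higher numbers stand for an effect only at larger amounts of compound and lower numbers for an effect already at smaller amounts), compound 1 (`COC1=C(C)C(=O)/C(=C(O)/C=C/c2ccc(OC)cc2)C(=O)C1(C)C`) gives 2.8 ug/mL as its value. Compound 2 (`COC1=C(C)C(=O)/C(=C(O)/C=C/c2cc(C)cc(C)c2)C(=O)C1(C)C`) has the entry "not determined" (no result reported) and therefore no single number on this read-out. Compound 3 (`COC1=C(C)C(=O)/C(=C(O)/C=C/c2cccs2)C(=O)C1(C)C`) carries thiophen-2-yl in place of 3,5-dimethylphenyl on a double-bonded chain carbon bound to a double-bonded chain carbon. Going by the values given here, with no measured step to size this change, no shift in either direction and none beyond the scatter is expected in this assay relative to the only number available, that of compound 1 (2.8 ug/mL). Compound 3 is expected at 3 ug/mL in this read-out, with an estimated range of 1.2 ug/mL to 8 ug/mL around it.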

Compound 3, concentration for half-maximal effect: 4 ug/mL
Beside the measured number, compound 3's estimate is 1.3-fold (0.12 log units) below it, within the range that was stated.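

In this assay, thiophen-2-yl in place of 4-methoxyphenyl on a double-bonded chain carbon bound to a double-bonded chain carbon gives a 1.4-fold higher number from compound 1 to compound 3 (0.15 log units; within the scatter). This first step at the position shows that a five-membered aromatic ring with a sulfur atom and a substituted six-membered carbon ring read alike here. The step from compound 2 cannot be read, and nothing available bears on a reason for this result. The compounds shown leave open whether an aminomethyl or carboxylic acid group on the ring would keep the number within the scatter.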